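Swapping the aryl ring on the amide carbonyl: cytotoxicity

The source may hold more compounds than are shown below. What is called first, only, known or untested is meant among the compounds shown, and "the series" means these compounds.

Measured compounds:
compound 1 `Cc1ccc(N(C(=O)c2ccccc2C)C(=S)OCCN2C(=O)c3ccccc3C2=O)cc1`: > 100000 nM
compound 2 `Cc1ccc(N(C(=O)c2ccc([N+](=O)[O-])cc2)C(=S)OCCN2C(=O)c3ccccc3C2=O)cc1`: 58000 nM
compound 3 `Cc1ccc(N(C(=O)c2cc(F)ccc2F)C(=S)OCCN2C(=O)c3ccccc3C2=O)cc1`: 62000 nM

Three compounds sharing one core and differing only in the aryl ring on a carbonyl carbon have been tested in an ADME assay on MT4 cells (Homo sapiens) for cytotoxicity, read by MTT assay; on this read-out higher numbers stand for lower toxicity in this test and lower numbers for higher toxicity in this test. For compound 1 the result is a limit of this assay rather than a number, (the limit of > 100000 nM in this assay, at which 1 of the 3 values shown sits). Compound 2 and compound 3 give numbers that cannot be told apart, since a 1.1-fold higher number from compound 2 to compound 3 (0.03 log units; within the scatter). The change from compound 1 to compound 2, an at least 1.7-fold lower number from compound 1 to compound 2 (0.23 log units; that floor lies within the scatter), and that from compound 1 to compound 3, an at least 1.6-fold lower number from compound 1 to compound 3 (0.20 log units; that floor lies within the scatter), both point to a lower number, but each is only a floor that sits within the scatter.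

Compound 4 `Cc1ccc(N(C(=O)c2ccc(Cl)c([N+](=O)[O-])c2)C(=S)OCCN2C(=O)c3ccccc3C2=O)cc1` has not yet been measured. It differs from compound 3 by 4-chloro-3-nitrophenyl in place of 2,5-difluorophenyl on a carbonyl carbon. The steps between the three aryl variants all lie within the scatter, so another aryl exchange at this place is expected to leave the number about where compound 3 stands. Compound 4 is therefore expected to give 55000 nM in this assay, within a range from 25000 nM to 110000 nM. The step this estimate implies, a 1.1-fold lower number from compound 3 to compound 4 (0.05 log units; within the scatter), is expected to stay within the scatter.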

Compound 4, half-maximal cytotoxic concentration: 47000 nM
For compound 4 the middle estimate is 1.2-fold (0.07 log units) above the measured one, within the range that was stated.
By their numbers in this assay, from the lowest: compounds 4, 2 and 3 (each within the scatter of the next). At a limit, above all of these: compound 1.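

In this assay, compound 4 carries a larger aryl group, 4-chloro-3-nitrophenyl, yet it cannot be told apart from the two other variants that give numbers, with a 1.3-fold lower number from compound 3 to compound 4 (0.12 log units; within the scatter) and a 1.2-fold lower number from compound 2 to compound 4 (0.09 log units; within the scatter). Among the compounds shown here, the first step at this position to clear the scatter is an at least 2.1-fold lower number from compound 1 to compound 4 (0.32 log units; beyond the scatter), so the 2-methylphenyl compound is now separated from at least one other aryl variant, although only modestly and with that size as a floor. Compound 1 is still a limit of the assay and not a number, and for this reason the true size of that step stays unknown: the limit of > 100000 nM in this assay, at which 1 of the 4 values shown sits.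

As far as these compounds go, all four compounds keep an aryl ring on this carbonyl carbon, so it remains open whether an amine, a carboxylic acid or a longer chain in its place would give a number in the same range. Plain phenyl is also absent from the set, which leaves open whether the methyl of the 2-methylphenyl group is what sets compound 1 apart from the other three.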